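Removing the methoxy group from compound 3

The compounds below may be only part of what the source reports. "The series", "measured", "known", "first", "only" and "open" are said of these compounds alone.

Measured in a functional assay on MV4-11 cells (Homo sapiens) for antiproliferative activity, read by CCK-8 assay, with a stated time of 72 h (a higher number here means a weaker inhibitor, a lower number a stronger inhibitor), as follows
compound 1 `Cn1cc(-c2ccccc2F)c2cc(C(=O)NCc3ccc(C(=O)Nc4ccccc4N)cc3)[nH]c2c1=O` gives 230 nM
compound 2 `CC(C)Oc1ccccc1-c1cn(C)c(=O)c2[nH]c(C(=O)NCc3ccc(C(=O)Nc4ccccc4N)cc3)cc12` gives 130 nM
compound 3 `COc1cccc(-c2cn(C)c(=O)c3[nH]c(C(=O)NCc4ccc(C(=O)Nc5ccccc5N)cc4)cc23)c1` gives 250 nM

Compound 3 sits within the usual scatter of the other two. Compound 4 `Cn1cc(-c2ccccc2)c2cc(C(=O)NCc3ccc(C(=O)Nc4ccccc4N)cc3)[nH]c2c1=O` has hydrogen in place of methoxy on an aromatic carbon and has not yet been measured. Within the data shown here, two steps bear on this change, each swapping one substituted phenyl for another: a 1.1-fold higher number from compound 1 to compound 3 (0.04 log units; within the scatter) and a 1.9-fold higher number from compound 2 to compound 3 (0.28 log units; within the scatter) both stay within the scatter. Among the measured compounds shown here, no measured step removes a group outright, so this evidence is indirect, and no step beyond the scatter is expected in this assay here. The expected step is a 1.3-fold lower number from compound 3 to compound 4 (0.10 log units; within the scatter) and lies within the scatter. Compound 4 is expected at about 200 nM with an estimated range from 100 nM to 400 nM in this measurement.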

Compound 4, half-maximal inhibitory concentration: 230 nM
Beside the measured number, compound 4's estimate is 1.2-fold (0.06 log units) below it; the range from low to high includes it.
By their numbers in this assay, from the lowest: compounds 2, 1, 4 and 3 (each within the scatter of the next).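

Within this assay the plain phenyl of compound 4 carries no group on that ring at all, yet removing the methoxy gives a 1.1-fold lower number from compound 3 to compound 4 (0.04 log units; within the scatter) and stays within the scatter. The other comparisons agree, with a 1.8-fold higher number from compound 2 to compound 4 (0.25 log units; within the scatter) and no change at the digits printed from compound 1 to compound 4 (within the scatter) also within the scatter, so hydrogen, fluoro, methoxy and isopropoxy on this phenyl cannot be told apart here. Nothing available gives a reason for this flat picture. Still open, going by these compounds, is whether an amine or a carboxylic acid on this ring would stay within the scatter too.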